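Swapping the bicyclic amide head of compound 1

The compounds below may be only part of what the source reports. "The series", "measured", "known", "first", "only" and "open" are said of these compounds alone.

Measured compounds:
compound 1 `O=C(NCc1ccc(S(=O)(=O)c2ccccc2)cc1)c1nc2ccncc2s1` gives 210 nM
compound 2 `O=C(NCc1ccc(S(=O)(=O)N2CCCCC2)cc1)c1cc2cnccc2o1` gives 140 nM
compound 3 `O=C(NCc1ccc(S(=O)(=O)N2CCCCC2)cc1)c1cc2ccncc2[nH]1` gives 1000 nM

Of the compounds shown here, three have been tested in an assay for inhibition of Nicotinamide phosphoribosyltransferase (Homo sapiens), read by mass spectrometry, with stated times of 15 min and 30 min; a higher number here means a weaker inhibitor, a lower number a stronger inhibitor. Compound 1 stands second highest of the three numbers; its nearest neighbour is compound 2, whose value lies within the scatter of compound 1, while compound 3 lies beyond the scatter on the weaker side. Compound 4 `O=C(NCc1ccc(S(=O)(=O)c2ccccc2)cc1)c1c[nH]c2ccncc12` has not yet been measured. It differs from compound 1 in one place: a group of 9 heavy atoms (7 carbon, 2 nitrogen; one five-membered aromatic ring with 1 hetero atom, one six-membered aromatic ring with 1 hetero atom) in place of a group of 9 heavy atoms (6 carbon, 2 nitrogen, 1 sulfur; one five-membered aromatic ring with 2 hetero atoms, one six-membered aromatic ring with 1 hetero atom), on a carbonyl carbon.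

Within the data shown here, only one measured step bears on this exchange. From compound 2 to compound 3 a bicyclic head without a hydrogen-bond donor was replaced by one carrying an aromatic amide-type hydrogen, and the result was a 7.1-fold higher number from compound 2 to compound 3 (0.85 log units; beyond the scatter). The change from compound 1 to compound 4 likewise introduces a donor-bearing bicyclic head on the carbonyl carbon, on a shared core otherwise identical to compound 1. A weakening step beyond the scatter is therefore expected, estimated at a 3.8-fold higher number from compound 1 to compound 4 (0.58 log units; beyond the scatter), though the differing starting head leaves it uncertain. Compound 4 is expected to give about 800 nM, with a range from 300 nM to 2500 nM.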

Compound 4, half-maximal inhibitory concentration: 1900 nM
For compound 4 the middle estimate is 2.4-fold (0.38 log units) below the measured one, and the stated range covers the measured number.
By their numbers in this assay, from the lowest: compounds 2 and 1 (each within the scatter of the next); then compounds 3 and 4 (each within the scatter of the next).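

On the carbonyl carbon of the shared core of compound 1, bringing in a head with one hydrogen-bond donor gives a 9.0-fold higher number from compound 1 to compound 4 (0.96 log units; beyond the scatter) in this assay. With a 7.1-fold higher number from compound 2 to compound 3 (0.85 log units; beyond the scatter), this makes two steps beyond the scatter in the same direction on two different cores, so the rise in the number is no longer tied to a single core, and neither step goes against it. The exchange also alters the hetero atoms and the acceptor count, and no available data explain why the number rises or separate these changes.

The compounds shown leave open how a methyl group on the ring nitrogen that carries the hydrogen would read in this assay. They also leave open whether the donor itself, rather than the other changes in the head, accounts for the step.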